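This account rests on a few compounds, and the source may have more. Where it says the series, first, only, none or still open, it means among the compounds named here.

Compound 1, `CCOCc1cc(CN2CCCCC2)c(O)c2ncccc12`, is the starting point of this small series; in a functional assay on MES-SA cells (Homo sapiens) for inhibition, with a stated time of 72 h (on this read-out higher numbers stand for weaker inhibition and lower numbers for stronger inhibition), compound 1 gives 8710 nM. Compound 2, `CC(C)OCc1cc(CN2CCCCC2)c(O)c2ncccc12`, carries methyl in place of hydrogen on a saturated chain carbon bound to an oxygen on a saturated carbon and a saturated chain carbon; in this assay compound 2 gives 6030 nM, and the measured step is a 1.4-fold lower number from compound 1 to compound 2 (0.16 log units; within the scatter). Compound 3, `COCc1cc(CN2CCC(C)CC2)c(O)c2ncccc12`, has a different core; how the core of compound 1 and the core of compound 3 differ is not broken down here. In this assay compound 3 gives 6170 nM, and its value and that of compound 2 lie within the scatter of each other.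

Compound 4, `CCOCc1cc(CN2CCC(C)CC2)c(O)c2ncccc12`, is not yet measured. It differs from compound 3 by methyl in place of hydrogen on a saturated chain carbon bound to an oxygen on a saturated carbon. For the measured compounds named here, this is the same kind of change as the one from compound 1 to compound 2, but not the same: there the place was on a saturated chain carbon bound to an oxygen on a saturated carbon and a saturated chain carbon, whereas here it is on a saturated chain carbon bound to an oxygen on a saturated carbon. For compound 4 the expected step is a 1.2-fold lower number from compound 3 to compound 4 (0.09 log units; within the scatter), set beside a 1.4-fold lower number from compound 1 to compound 2 (0.16 log units; within the scatter), because a 1.4-fold lower number from compound 1 to compound 2 (0.16 log units; within the scatter) lay within the scatter. Compound 4 is therefore estimated at 5000 nM, expected between 2500 nM and 10000 nM.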

Compound 4, half-maximal inhibitory concentration: 4070 nM
Compound 4: middle estimate off by 1.2-fold (0.09 log units), on the high side, within the range that was stated.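

In this assay, methyl in place of hydrogen on a saturated chain carbon bound to an oxygen on a saturated carbon gives a 1.5-fold lower number from compound 3 to compound 4 (0.18 log units; within the scatter) and so stays as small as the step seen on the other core, the two agreeing within the scatter: the same change on two cores in this assay, a 1.4-fold lower number (0.16 log units; within the scatter) from compound 1 to compound 2 and a 1.5-fold lower number (0.18 log units; within the scatter) from compound 3 to compound 4, 1.0-fold (0.02 log units) apart, within the scatter of two such steps. This shows that the change carries between these two cores without any visible difference in size, but since each step lies within the scatter on its own, it does not show that the change itself lowers the number, and two cores in one assay set no rule for the series. For the compounds shown here, the only step beyond the scatter belongs to a different change, methyl in place of hydrogen on a saturated ring carbon, which gives a 2.1-fold lower number from compound 1 to compound 4 (0.33 log units; beyond the scatter) and is seen once, on one pair.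

As far as these compounds go, whether that ring step repeats on another core remains open. So does what a longer chain such as butoxymethyl, or a carboxylic acid, would give in place of the ethoxymethyl group.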